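A few compounds are considered here, and "the series" means these few. Any claim that something is new, unique, unknown or untested is made for them only; others in the source may bear on it.

Compound 1 `C=CC(=O)Nc1cc(Nc2ncc3ncn(-c4ccc(F)cc4)c3n2)c(OC)cc1N(C)CCN(C)C` gives 12000 nM in an ADME assay on HT-29 cells (Homo sapiens) for cytotoxicity, read by MTT assay, with a stated time of 72 h; a lower number here means a stronger inhibitor, a higher number a weaker inhibitor.
Compound 2 `C=CC(=O)Nc1cc(Nc2ncc3ncn(-c4ccccc4F)c3n2)c(OC)cc1N(C)CCN(C)C` gives 9750 nM in this assay.
Compound 3 `C=CC(=O)Nc1cc(Nc2ncc3ncn(-c4ccc(Cl)cc4Cl)c3n2)c(OC)cc1N(C)CCN(C)C` gives 20600 nM in this assay.

Compound 3 has the highest number of the three in this assay: the change from 4-fluorophenyl to 2,4-dichlorophenyl brings a 1.7-fold higher number from compound 1 to compound 3 (0.23 log units; within the scatter), and that from 2-fluorophenyl brings a 2.1-fold higher number from compound 2 to compound 3 (0.32 log units; beyond the scatter), a modest step, while the two fluorophenyl compounds differ by a 1.2-fold lower number from compound 1 to compound 2 (0.09 log units; within the scatter). Compound 4 `C=CC(=O)Nc1cc(Nc2ncc3ncn(C4CCCC4)c3n2)c(OC)cc1N(C)CCN(C)C` is made from compound 3 by cyclopentyl in place of 2,4-dichlorophenyl on an aromatic nitrogen. Within the data shown here, none of the measured steps exchanges an aromatic ring for a saturated one, so they bear on this change only by showing how narrow the spread among the three aryl variants has been. The step in this assay is therefore expected to be small, if anything toward a lower number, a 1.9-fold lower number from compound 3 to compound 4 (0.27 log units; within the scatter). Compound 4 is estimated at 11000 nM, within a range of 4000 nM to 30000 nM.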

Compound 4, half-maximal inhibitory concentration: 20900 nM
Estimate against measurement, compound 4: 1.9-fold (0.28 log units) below; the range from low to high includes it.
By their numbers in this assay, from the lowest: compounds 2, 1, 3 and 4 (each within the scatter of the next, the first and the last beyond it).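

In this assay, among these compounds, the first exchange of an aromatic ring for a saturated one on this aromatic nitrogen shows cyclopentyl level with 2,4-dichlorophenyl (a 1.0-fold higher number from compound 3 to compound 4 (0.01 log units; within the scatter)) and with 4-fluorophenyl (a 1.7-fold higher number from compound 1 to compound 4 (0.24 log units; within the scatter)), while only the comparison with 2-fluorophenyl passes the scatter, as a modest step (a 2.1-fold higher number from compound 2 to compound 4 (0.33 log units; beyond the scatter)). Among these compounds, then, an aromatic ring at this position is not needed to keep the number in this range. Nothing measured here explains this result. The compounds shown leave open whether a group of another kind on this nitrogen, such as an amine, a carboxylic acid or a longer chain, would move the number out of this narrow band.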